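The source may hold more compounds than are shown below. What is called first, only, known or untested is meant among the compounds shown, and "the series" means these compounds.

Measured so far in a functional assay for activation of Alpha-1A adrenergic receptor (Homo sapiens), read by calcium flux; a lower number here means that less compound is needed, a higher number that more compound is needed for the effect:
compound 1 `Cc1nc(-c2ccccc2NCC2=NCCN2)cs1`, 4.47 nM
compound 2 `c1cnc(-c2ccccc2NCC2=NCCN2)nc1`, 10 nM

Compound 2 stands at the highest of the two numbers in this assay; its nearest neighbour is compound 1, separated from it by a 2.2-fold higher number from compound 1 to compound 2 (0.35 log units; beyond the scatter). That single measured step exchanges one aromatic ring for another on the shared core of compound 1.

Compound 3 `CCO/N=C(\C)c1ccccc1NCC1=NCCN1` is not yet measured. It differs from compound 2 by a group of 6 heavy atoms (4 carbon, 1 nitrogen, 1 oxygen; no ring) in place of a group of 6 heavy atoms (4 carbon, 2 nitrogen; one six-membered aromatic ring with 2 hetero atoms), on an aromatic carbon. Among the compounds with values here, no measured step exchanges a ring for a group with no ring, so the only step at hand, a 2.2-fold higher number from compound 1 to compound 2 (0.35 log units; beyond the scatter), bears on it only loosely: it shows that changing this group on the core shifts the number modestly. The step expected here is estimated as a 1.5-fold higher number from compound 2 to compound 3 (0.18 log units; within the scatter), leaning toward a higher number with the direction uncertain. Compound 3 is therefore estimated at 15 nM in this assay, with a range from 4 nM to 60 nM.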

Compound 3, half-maximal effective concentration: 52.5 nM
Compound 3: the middle estimate sits 3.5-fold (0.54 log units) below what was measured, within the range that was stated.
By their numbers in this assay, from the lowest: compound 1; then compound 2; then compound 3.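

In this assay, the group with no ring on this aromatic carbon stands higher than both aromatic rings, with a 5.3-fold higher number from compound 2 to compound 3 (0.72 log units; beyond the scatter) and a 12-fold higher number from compound 1 to compound 3 (1.07 log units; beyond the scatter). The position therefore accepts a group with no ring and the compound still gives a measurable number, but both aromatic groups shown need less compound, and only the step from the 2-methyl-1,3-thiazol-4-yl compound is printed as large. Nothing available explains this shift.

With a single ring-free group in the series, the loss of the ring cannot be separated from the identity of this particular group. A phenyl ring, a simple amine or a longer alkoxy chain at this position would help to show whether an aromatic ring is what keeps the number low.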